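Replacing a 4-chlorophenyl with 3-methylphenyl on a benzyl arm

The source may report more compounds than this note shows. Statements on the series, on what has been measured and on what is new or still open speak of the compounds shown alone.

Compound 1, `CSCC[C@H](NC(=O)c1ccc(NCc2cncn2Cc2ccccc2C#N)cc1-c1ccccc1)C(=O)O`: > 10 uM in a functional assay on NIH3T3 cells (Mus musculus); on this read-out higher numbers stand for an effect only at larger amounts of compound and lower numbers for an effect already at smaller amounts
Compound 2, `CSCC[C@H](NC(=O)c1ccc(NCc2cncn2Cc2cccc(C)c2)cc1-c1ccccc1)C(=O)O`: > 10 uM
Compound 3, `COC(=O)[C@H](CCSC)NC(=O)c1ccc(NCc2cncn2Cc2ccc(Cl)cc2)cc1-c1ccccc1`: > 10 uM

Compound 3 stands only at a limit in this assay: its value of > 10 uM is a limit of the assay, not a number. The same holds for compound 1, whose > 10 uM is a limit. Compound 2 likewise shows only a limit, > 10 uM.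

Compound 4, `COC(=O)[C@H](CCSC)NC(=O)c1ccc(NCc2cncn2Cc2cccc(C)c2)cc1-c1ccccc1`, differs from compound 3 in one place: 3-methylphenyl in place of 4-chlorophenyl on a saturated chain carbon bound to an aromatic nitrogen. Going by the values given here, the one measured step that touches a related change is a step that the two limits leave unreadable from compound 1 to compound 2, but with both ends at a limit its size cannot be read. Among the compounds with values here, no measured step exchanges a 4-chlorophenyl for a 3-methylphenyl, so nothing shows what size of step to expect in this assay.

What is known is the limit of > 10 uM in this assay, at which 3 of the 3 values shown sit. From that, compound 4 is expected to sit near the same limit, with an estimated 20 uM spanning 5 uM to 100 uM, and the step that the limit leaves unreadable from compound 3 to compound 4 is expected to be small or unreadable.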

Compound 4, concentration for half-maximal effect: > 10 uM
Compound 4: a limit, no number (the forecaster's own chance of this, stated with the estimate: 80%); the middle value is on the limit's open side.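

Compound 4 gives only a limit in this assay, as do compound 2 and compound 3, so neither step reaching compound 4 can be read. The compounds shown leave open what real value any of them has, and so what either change does: the limit of > 10 uM in this assay, at which 4 of the 4 values shown sit.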